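Pentyl on selenium: carrying one measured step to compound 4

The compounds below may be only part of what the source reports. "The series", "measured", "known", "first", "only" and "open" are said of these compounds alone.

Compound 2 `[SeH]c1nc(NCc2ccccc2)c2ccccc2n1` bears a hydrogen on the selenium. In a functional assay on CCRF-CEM cells (Homo sapiens) for cytotoxicity, read by MTT assay, with a stated time of 72 h (a higher number here means a weaker inhibitor of growth, a lower number a stronger inhibitor of growth), compound 2 gives > 100000 nM, which is a limit of the assay rather than a number. Compound 1 `CCCCC[Se]c1nc(NCc2ccccc2)c2ccccc2n1` differs by pentyl in place of hydrogen on a selenium. In this assay compound 1 gives 72500 nM. The step of an at least 1.3-fold lower number from compound 2 to compound 1 (0.13 log units; that floor lies within the scatter) has only a floor, because the limit of > 100000 nM in this assay, at which 1 of the 3 values shown sits, sets one end of it. Compound 3 `Nc1nc([SeH])nc2ncccc12` keeps the selenium-bound hydrogen on a different core; the difference between the two cores is not broken down here. In this assay compound 3 gives 61500 nM. Compound 4 `CCCCC[Se]c1nc(N)c2cccnc2n1` applies the same change to compound 3: pentyl in place of hydrogen on a selenium. As far as these compounds go, the step from compound 3 to compound 4 is expected to be small, a 1.4-fold lower number from compound 3 to compound 4 (0.14 log units; within the scatter), resting on the measured step of an at least 1.3-fold lower number from compound 2 to compound 1 (0.13 log units; that floor lies within the scatter) whose size beyond its floor is unknown. Compound 4 is therefore estimated at 45000 nM, between 20000 nM and 95000 nM.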

Compound 4, concentration for total growth inhibition: 42800 nM
Compound 4: middle estimate off by 1.1-fold (0.02 log units), on the high side; low and high end bracket the measured number.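

In this assay pentyl in place of hydrogen on a selenium gives a 1.4-fold lower number from compound 3 to compound 4 (0.16 log units; within the scatter), a step too small to read as an effect on its own. Set beside the earlier step, the change reads this way on the two cores: the same change on two cores in this assay, an at least 1.3-fold lower number (0.13 log units; that floor lies within the scatter) from compound 2 to compound 1 and a 1.4-fold lower number (0.16 log units; within the scatter) from compound 3 to compound 4; the limit leaves it open whether they differ. Compound 2 stands at a limit, so the data show neither that the step carries over unchanged between the cores nor that it differs: the limit of > 100000 nM in this assay, at which 1 of the 4 values shown sits.

The compounds shown leave open whether a longer chain or a methyl on the selenium would give a step beyond the scatter on either core. They also leave open what a pentyl chain carrying an amine or a carboxylic acid would give.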